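Chain length at the pyridyl cyanoguanidine series, phenyl variant

The compounds below may be only part of what the source reports. "The series", "measured", "known", "first", "only" and "open" are said of these compounds alone.

Measured so far in a functional assay on MCF7 cells (Homo sapiens) for cytotoxicity; a lower number here means a stronger inhibitor, a higher number a weaker inhibitor:
compound 1 `CC1C(=O)N(CCCCCCOc2ccc(Cl)cc2)/C(=N\C#N)N1c1ccncc1`: 270 nM
compound 2 `N#C/N=C1\N(CCCCCOc2ccc(Cl)cc2)C(=O)C(c2ccccc2)N1c1ccncc1`: 1000 nM

Compound 2 gives the higher of the two numbers in this assay; compound 1 sits well beyond the usual scatter from it. The two differ in more than one place, so their gap is not assigned to a single change.

Compound 3 `N#C/N=C1\N(CCCCCCOc2ccc(Cl)cc2)C(=O)C(c2ccccc2)N1c1ccncc1` is the next member awaiting a number in this assay. It changes compound 2 only at the chain: (4-chlorophenoxy)methyl in place of 4-chlorophenoxy on a saturated chain carbon, five bonds along the chain from an amide-type nitrogen in a ring. The same chain length is already present in compound 1, which carries a methyl rather than a phenyl on the shared core.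

Among the compounds with values here, no measured pair isolates this single chain step, so the expectation rests on the direction of the two numbers alone. A modest move toward a lower number is expected, with the step from compound 2 to compound 3 estimated at a 1.7-fold lower number from compound 2 to compound 3 (0.22 log units; within the scatter), though a result within the scatter would not surprise.

For compound 3 in this assay the estimate is 600 nM, with a plausible range from 200 nM to 2000 nM.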

Compound 3, half-maximal inhibitory concentration: 1130 nM
Compound 3: the middle estimate sits 1.9-fold (0.27 log units) below what was measured; the range from low to high includes it.
By their numbers in this assay, from the lowest: compound 1; then compounds 2 and 3 (each within the scatter of the next).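

In this assay the chain step, (4-chlorophenoxy)methyl in place of 4-chlorophenoxy on a saturated chain carbon, gives a 1.1-fold higher number from compound 2 to compound 3 (0.05 log units; within the scatter) and so leaves no readable change at this position while phenyl sits on the shared core. Phenyl in place of methyl on a saturated ring carbon, with the chain held the same, gives a 4.2-fold higher number from compound 1 to compound 3 (0.62 log units; beyond the scatter) and is the only single-place step so far that lies beyond the scatter, which makes the ring carbon rather than the chain the more responsive of the two places among these three compounds. Nothing at hand bears on why either step comes out as it does.

The compounds shown leave open whether the chain step would read the same with methyl on the shared core, since the two steps are available only around compound 3 and no chain pair carries the methyl. They also leave open how far the flat reading extends along the chain, for instance to a longer chain, and whether an amine or a carboxylic acid at the far end of the chain in place of 4-chlorophenoxy would move the number in this series.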